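The source may hold more compounds than are shown below. What is called first, only, known or untested is meant among the compounds shown, and "the series" means these compounds.

Measured in an assay on Sf9 cells for inhibition of histone deacetylase 11 (Homo sapiens), read by fluorescence, tested at 0.5 uM; a lower number here means less inhibition, a higher number more inhibition at the concentration tested (going by the name of the read-out):
- compound 1 `O=C(/C=C/c1cn([C@@H]2C[C@H](CO)N(CCCc3ccccc3)C2)nn1)NO` gives 12%.
- compound 2 `O=C(/C=C/c1cn([C@@H]2C[C@@H](CO)N(Cc3ccccc3)C2)nn1)NO` is known only by a limit of the assay, < 10%.

Compound 2 therefore stands at the floor of what this assay reports, with no number of its own. One of the two values shown sits at that limit (the limit of < 10% in this assay, at which 1 of the 2 values shown sits). The value of compound 1 lies within the usual scatter of that floor as well, so neither compound shows inhibition at this concentration that could be ordered against the other.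

Compound 3 `O=C(/C=C/c1cn([C@@H]2C[C@H](CO)N(Cc3ccccc3)C2)nn1)NO` is the unmeasured counterpart of compound 2: the two compounds have the same atoms and bonds and differ only in configuration as drawn: 1 of 3 stereo elements differ; a stereocentre at a saturated ring carbon is drawn S in compound 2 and R in compound 3. For the measured compounds named here, no step between measured compounds is available in this set, so the series gives no measured size for what a change of configuration at this ring carbon does. The step of a number no lower from compound 2 to compound 3 (the limit leaves the size open) is expected to be none beyond the scatter, in either direction. Compound 3 is expected to give about 10% in this assay, within 4% to 22%, with a fair chance that only a limit is reported again.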

Compound 3, a percentage reported as inhibition, at one concentration (the size of the read-out at that concentration, not a potency): < 10%
Compound 3 was reported as a limit (the forecaster's own chance of this, stated with the estimate: 50%); the middle value sits exactly at the limit.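

In this assay compound 3 is known only by a limit of the assay, < 10%. For the compounds shown here, with compound 2 also known only by a limit, the step from S to R at this saturated ring carbon cannot be read in either direction, and the floor now holds most of the values shown: the limit of < 10% in this assay, at which 2 of the 3 values shown sit. The one readable step, phenyl in place of phenethyl, is a number at least 2 percentage points lower from compound 1 to compound 3 (that floor lies within the scatter), so this change on the amine nitrogen in the ring shows no difference that can be told apart from the floor.

From the compounds shown here alone, whether the configuration at this ring carbon matters at all stays open, since it could be read only in a pair standing clear of the floor. Also open, going by these compounds, is whether a longer chain, or an amine or a carboxylic acid in place of the phenyl at the end of the chain, would lift the read-out in this assay beyond the scatter.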